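Pentyl on selenium: cytotoxicity notes on the series

The compounds below may be only part of what the source reports. "The series", "measured", "known", "first", "only" and "open" are said of these compounds alone.

Four compounds are compared in a functional assay on CCRF-CEM cells (Homo sapiens) for cytotoxicity, read by MTT assay, with a stated time of 72 h; on this read-out higher numbers stand for lower toxicity in this test and lower numbers for higher toxicity in this test. Compound 1 `CCCCC[Se]c1nc(NCc2ccc(SC)cc2)c2ccccc2n1` and compound 2 `CSc1ccc(CNc2nc([SeH])nc3ccccc23)cc1` share one core; compound 3 `Nc1nc([SeH])nc2ncccc12` and compound 4 `CCCCC[Se]c1nc(N)c2cccnc2n1` share another, and the difference between the two cores is not broken down here.

In this assay compound 2 reaches only a limit, > 100000 nM. Compound 1 likewise reaches only a limit in this assay, > 100000 nM. The change from compound 2 to compound 1 is pentyl in place of hydrogen on a selenium, and its step, a step that the two limits leave unreadable from compound 2 to compound 1, cannot be read because both values sit at the limit of > 100000 nM in this assay, at which 2 of the 3 values shown sit. For the measured compounds named here, compound 3 is the one compound with a number in this assay, 92100 nM.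

Compound 4 differs from compound 3 by pentyl in place of hydrogen on a selenium, the same change as from compound 2 to compound 1, at a place described in the same words. Going by the values given here, the measured pair gives no size for this step, so the expectation for compound 4 rests on compound 3 alone, with 92100 nM as the anchor. Compound 4 itself may again return only a limit in this assay, and that possibility is kept in view. For compound 4 the estimated step is a 1.0-fold lower number from compound 3 to compound 4 (0.01 log units; within the scatter). Compound 4 is therefore expected at 90000 nM, within a range from 30000 nM to 300000 nM.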

Compound 4, concentration lethal to 50% of the cells: 72600 nM
The estimate for compound 4 lay 1.2-fold (0.09 log units) above the measured number; measured number inside the range.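

The new step is a 1.3-fold lower number from compound 3 to compound 4 (0.10 log units; within the scatter), so on the second of the two cores, pentyl in place of hydrogen on a selenium brings no change in this assay that can be told apart from the scatter. Compound 1 and compound 2 each give only a limit, so the same change on their shared core has no readable size to set beside this one: the limit of > 100000 nM in this assay, at which 2 of the 4 values shown sit. Carrying the change from one core to the other is therefore neither confirmed nor contradicted, since a single readable step describes only its own core and gives no basis for a rule across the series.

Open, on these data alone, is whether another group on the selenium, such as a longer chain like octyl, a benzyl group, or a chain ending in an amine or a carboxylic acid, would move the number beyond the scatter on either core. Also open, as far as these compounds go, is the size of any step on the core of compound 1, which could be compared with the new step only if both members of a pair on that core gave numbers rather than limits.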